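Swapping a biphenyl end for naphthalene in a cytotoxicity assay

The compounds below may be only part of what the source reports. "The series", "measured", "known", "first", "only" and "open" are said of these compounds alone.

Measured compounds (each value is a limit of the assay, not a number):
- Compound 1 `O=C(O)C1=CO[C@@H](O[C@@H]2O[C@H](COCc3ccccc3)[C@@H](OCc3ccccc3)[C@H](OCc3ccccc3)[C@H]2OCc2ccccc2)[C@@H]2C(COCc3ccccc3)=CC[C@H]12`: > 200000 nM
- Compound 2 `O=C(Nc1ccc(Oc2ccccc2)cc1)C1=CO[C@@H](O[C@@H]2O[C@H](COCc3ccccc3)[C@@H](OCc3ccccc3)[C@H](OCc3ccccc3)[C@H]2OCc2ccccc2)[C@@H]2C(COCc3ccccc3)=CC[C@H]12`: > 200000 nM
- Compound 3 `CCOS(=O)(=O)/C=C/c1ccc(OCC2=CC[C@@H]3C(C(=O)Nc4ccc(Oc5ccc(-c6ccccc6)cc5)cc4)=CO[C@@H](OC)[C@H]23)cc1`: > 200000 nM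

The read-out here is an ADME assay on CHO cells (Cricetulus griseus) for cytotoxicity, read by MTT assay, with a stated time of 24 h; on this read-out higher numbers stand for weaker inhibition and lower numbers for stronger inhibition. Compound 3 gives > 200000 nM, which is a limit and not an exact figure. It shares this position with the other two measured compounds: the limit of > 200000 nM in this assay, at which 3 of the 3 values shown sit. Among the measured compounds shown here, no measured pair gives a step that could serve as a guide.

The next compound is compound 4 `CCOS(=O)(=O)/C=C/c1ccc(OCC2=CC[C@@H]3C(C(=O)Nc4ccc(Oc5ccc6ccccc6c5)cc4)=CO[C@@H](OC)[C@H]23)cc1`, which differs from compound 3 at one place: naphthalen-2-yl in place of 4-phenylphenyl on an oxygen on an aromatic ring. In words, naphthalen-2-yl stands in place of 4-phenylphenyl on an oxygen on an aromatic ring.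

In this assay, no step beyond the scatter is expected, in either direction, because compound 3 sits at > 200000 nM. A further limit is the likeliest report.

Compound 4 is estimated at 200000 nM, with an expected range from 120000 nM to 300000 nM. This estimate means an expected a number no higher from compound 3 to compound 4 (the limit leaves the size open).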

Compound 4, half-maximal inhibitory concentration: > 200000 nM
Compound 4: only a limit was reported (the forecaster's own chance of this, stated with the estimate: 85%); the middle value sits exactly at the limit.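

No step can be read from compound 3 to compound 4 in this assay, because both results are limits and not numbers: the limit of > 200000 nM in this assay, at which 4 of the 4 values shown sit.

The compounds shown leave open whether naphthalen-2-yl and 4-phenylphenyl differ at all here, and what exact value any of the four compounds would give.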